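The source may hold more compounds than are shown below. What is called first, only, known or untested is meant among the compounds shown, and "the series" means these compounds.

Measured so far:
compound 1, `C=CCn1c(SCC(=O)c2ccccc2)nnc1-c1ccccc1`, 70%
compound 2, `O=C(CSc1nnc(-c2ccccc2)n1-c1ccccc1)c1ccccc1`, 64%
compound 3, `C=CCn1c(SCC(=O)c2ccccc2)nnc1-c1cc(OC)c(OC)c(OC)c1`, 66%

All three were read in a functional assay on the whole organism (strain albino) for inhibition, with Rattus norvegicus as the target, read by paw edema, with a stated time of 3 h, at a dose of 0.28 mmol/kg by the oral route; on this read-out higher numbers stand for more inhibition at the one dose given (going by the name of the read-out) and lower numbers for less inhibition. Compound 1 and compound 2 differ in one place: phenyl in place of allyl on an aromatic nitrogen. On this assay the step is a number 6 percentage points lower from compound 1 to compound 2 (within the scatter). Compound 3 carries a different core; how the core of compound 1 and the core of compound 3 differ is not broken down here. Compound 3 and compound 2 give numbers within the scatter of each other, as do compound 3 and compound 1.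

Compound 4, `COc1cc(-c2nnc(SCC(=O)c3ccccc3)n2-c2ccccc2)cc(OC)c1OC`, is not yet measured. It differs from compound 3 by phenyl in place of allyl on an aromatic nitrogen. For the measured compounds named here, this is the same kind of change as the one from compound 1 to compound 2, not the same: in compound 1 the changed nitrogen is next to the ring atom that bears a phenyl group (6 heavy atoms), in compound 3 next to the ring atom that bears a (benzoylmethyl)sulfanyl group. Taking the step of a number 6 percentage points lower from compound 1 to compound 2 (within the scatter) as the only guide, the step from compound 3 to compound 4 is expected to be a number 6 percentage points lower from compound 3 to compound 4 (within the scatter), a change within the scatter. Compound 4 is therefore estimated at 60%, with a range from 48% to 72%.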

Compound 4, a percentage reported as inhibition, in the whole organism at one dose (the size of the read-out at that dose, not a potency): 68%
For compound 4 the middle estimate is 8 percentage points below the measured one, and the stated range covers the measured number.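

In this assay, phenyl in place of allyl on an aromatic nitrogen gives a number 2 percentage points higher from compound 3 to compound 4 (within the scatter), and the two steps for this change do not separate: the same change on two cores in this assay, a number 6 percentage points lower (within the scatter) from compound 1 to compound 2 and a number 2 percentage points higher (within the scatter) from compound 3 to compound 4, 8 percentage points apart, within the scatter of two such steps. On these two cores, the exchange of allyl for phenyl therefore leaves this assay within the scatter, and nothing here marks either core as responding differently. This does not show that the change is without effect in general, since the comparison rests on two pairs at a single dose and time, and a core dependence smaller than the scatter would go unseen.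

Allyl and phenyl are the only groups shown on that nitrogen, so a longer alkyl chain, a benzyl group or a chain ending in an amine remains open on either core. Also open, going by these compounds, is whether the same picture holds when a carboxylic acid takes the place of the benzoyl part of the (benzoylmethyl)sulfanyl group.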